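The source may hold more compounds than are shown below. What is called first, only, known or untested is meant among the compounds shown, and "the series" means these compounds.

Measured compounds:
compound 1, `Cc1c(Br)sc(N)c1C(=O)c1ccc(Cl)cc1`: 1%
compound 2, `Nc1sc(-c2ccccc2)c(-c2ccccc2)c1C(=O)c1ccc(Cl)cc1`: 1%
compound 3, `CC(C)(C)Cc1c(-c2ccoc2)sc(N)c1C(=O)c1ccc(Cl)cc1`: 1%

All three readings come from an assay on CHO cells for displacement of a labelled ligand from adenosine receptor A1 (Homo sapiens), read by scintillation counting, tested at 10 uM; on this read-out lower numbers stand for less inhibition and higher numbers for more inhibition at the one concentration tested (going by the name of the read-out). Compound 3 stands level with compound 1 and compound 2 at the digits shown; its nearest neighbour is compound 1 and its furthest compound 2, and neither gap goes beyond the scatter. Compound 4, `CC(C)(C)Cc1c(-c2c(F)cccc2F)sc(N)c1C(=O)c1ccc(Cl)cc1`, has not yet been run in this assay. It differs from compound 3 in a single place: 2,6-difluorophenyl in place of furan-3-yl on an aromatic carbon. Going by the values given here, no measured pair sets the size of this change. The three measured compounds, though built differently around the shared core, all give the same reading. Compound 4 is therefore expected to show a step of a number 1 percentage points higher from compound 3 to compound 4 (within the scatter) with no size beyond the scatter. The expected value for compound 4 is 2%, within 0% to 12%.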

Compound 4, a percentage reported as inhibition, at one concentration (the size of the read-out at that concentration, not a potency): 1%
For compound 4 the middle estimate is 1 percentage points above the measured one; low and high end bracket the measured number.
By their numbers in this assay, from the lowest: compounds 1, 2, 3 and 4 (each within the scatter of the next).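

In this assay, going by these compounds alone, 2,6-difluorophenyl in place of furan-3-yl on the aromatic carbon next to the ring sulfur gives no change at the digits printed from compound 3 to compound 4 (within the scatter) and is the first step read at this position. With the neopentyl group held fixed, a six-membered aromatic ring of carbon only reads the same here as a five-membered aromatic ring with one hetero atom. Nothing at hand explains this result.

As far as these compounds go, whether an amine or a carboxylic acid on this carbon would move the reading stays open. So does whether a longer chain in place of the neopentyl group would do so.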